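This account rests on a few compounds, and the source may have more. Where it says the series, first, only, none or still open, it means among the compounds named here.

Of the compounds shown here, three built on one shared core have been tested in a functional assay on liver (Sus scrofa) for inhibition of squalene monooxygenase (Homo sapiens), using microsomes; on this read-out lower numbers stand for stronger inhibition and higher numbers for weaker inhibition. Compound 1 `CCN(C/C=C/C#CC(C)(C)C)Cc1cccc(OC[Si](C)(C)c2ccc(OC)cc2)c1` gives 870 nM, compound 2 `CCN(C/C=C/C#CC(C)(C)C)Cc1cccc(OC[Si](C)(C)c2ccc(S)cc2)c1` gives 8000 nM, and compound 3 `C=Cc1ccc([Si](C)(C)COc2cccc(CN(CC)C/C=C/C#CC(C)(C)C)c2)cc1` gives 70 nM. Compound 3 stands lowest of the three: a 12-fold lower number from compound 1 to compound 3 (1.09 log units; beyond the scatter) and a 110-fold lower number from compound 2 to compound 3 (2.06 log units; beyond the scatter), while a 9.2-fold higher number from compound 1 to compound 2 (0.96 log units; beyond the scatter). Compound 4 `CCN(C/C=C/C#CC(C)(C)C)Cc1cccc(OC[Si](C)(C)CCc2ccccc2)c1` differs from compound 3 by phenethyl in place of 4-vinylphenyl on a silicon. Among the compounds with values here, no measured step removes the aromatic ring from the silicon; the three steps only exchange the group on that ring, yet each moved this assay beyond the scatter. Compound 1, which carries methoxy on that ring, gives 870 nM, and that region serves as the guide. A rise is therefore expected, an 8.6-fold higher number from compound 3 to compound 4 (0.93 log units; beyond the scatter). Compound 4 is estimated at 600 nM, within 150 nM to 2500 nM.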

Compound 4, half-maximal inhibitory concentration: > 10000 nM
Compound 4: no number, only a limit (the forecaster's own chance of this, stated with the estimate: 5%); middle value at least 16-fold (1.22 log units) from the limit.
By their numbers in this assay, from the lowest: compound 3; then compound 1; then compound 2. At a limit, above all of these: compound 4.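

Phenethyl and 4-vinylphenyl on the silicon count the same heavy atoms and one aromatic ring each, yet the exchange gives an at least 140-fold higher number from compound 3 to compound 4 (2.15 log units; beyond the scatter) and so shows this position answering to more than the group on the ring, the only thing the earlier steps changed. The same exchange gives an at least 11-fold higher number from compound 1 to compound 4 (1.06 log units; beyond the scatter) while an at least 1.2-fold higher number from compound 2 to compound 4 (0.09 log units; that floor lies within the scatter) is a floor that separates nothing. For compound 4 the value is a limit and not a number: the limit of > 10000 nM in this assay, at which 1 of the 4 values shown sits.

The compounds shown leave open whether benzyl or unsubstituted phenyl on the silicon would keep the low number of compound 3, and how far compound 4 lies past its limit.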